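Series notes: oxygen-ring variation on the amine side chain

The source may report more compounds than this note shows. Statements on the series, on what has been measured and on what is new or still open speak of the compounds shown alone.

Compound 2 `CCc1nn2c(-c3c(C)cc(C)cc3OC)cccc2c1N(CC1CCOCC1)CC1CC1` carries an oxan-4-yl group on the saturated chain carbon bound to the ring nitrogen, paired with a cyclopropylmethyl arm. In an assay on HEK293 cells for displacement of a labelled ligand from corticotropin-releasing factor receptor 1 (Homo sapiens), read by scintillation counting, with a stated time of 2 h (on this read-out lower numbers stand for stronger inhibition and higher numbers for weaker inhibition), compound 2 gives 22 nM. Compound 3 `CCc1nn2c(-c3c(OC)cc(C)cc3OC)cccc2c1N(CC1CCOCC1)CC1CC1` stands level with it in this assay at 22 nM, so compound 2 and compound 3 share the lowest numbers of the three; compound 1 `CCc1nn2c(-c3c(C)cc(C)cc3OC)cccc2c1N(CC1CC1)CC1CCCO1` gives 34 nM in this assay, a difference of a 1.5-fold lower number from compound 1 to compound 2 (0.19 log units; within the scatter), which stays within scatter.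

Compound 4 `CCc1nn2c(-c3c(C)cc(C)cc3OC)cccc2c1N(CC1CC1)CC1CCOC1` differs from compound 2 by oxolan-3-yl in place of oxan-4-yl on a saturated chain carbon bound to a nitrogen on an aromatic ring. The step that bears on it is the earlier ring exchange a 1.5-fold lower number from compound 1 to compound 2 (0.19 log units; within the scatter), where moving between oxolan-2-yl and oxan-4-yl produced nothing beyond scatter. The methyl-to-methoxy step no change at the digits printed from compound 2 to compound 3 (within the scatter) does not concern this position. A ring of the same kind, shifted in size and attachment point, is therefore expected to give no step beyond scatter in this assay, estimated as a 1.3-fold higher number from compound 2 to compound 4 (0.10 log units; within the scatter). Compound 4 is thus expected near 28 nM in this assay, within 12 nM to 65 nM.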

Compound 4, half-maximal inhibitory concentration: 38 nM
The estimate for compound 4 lay 1.4-fold (0.13 log units) below the measured number, and the stated range covers the measured number.
By their numbers in this assay, from the lowest: compounds 2, 3, 1 and 4 (each within the scatter of the next).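

With the oxolan-3-yl compound in hand, ring size and attachment point, which changed together from compound 1 to compound 2, can be read apart at the saturated chain carbon bound to a nitrogen on an aromatic ring. In this assay, changing ring size and attachment point together from oxan-4-yl to oxolan-3-yl gives a 1.7-fold higher number from compound 2 to compound 4 (0.24 log units; within the scatter), while moving only the attachment point of the five-membered ring, from oxolan-2-yl to oxolan-3-yl, gives a 1.1-fold higher number from compound 1 to compound 4 (0.05 log units; within the scatter), so neither change leaves the scatter across these three oxygen rings. No available data explain these numbers.

Still open, going by these compounds, is whether replacing the oxygen ring with cyclohexyl or with a piperidin-4-yl amine would give a step beyond the scatter. A carboxylic acid on the same chain carbon is a further open case.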